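The source may hold more compounds than are shown below. What is called first, only, known or untested is meant among the compounds shown, and "the series" means these compounds.

Measured in a functional assay on BXPC-3 cells (Homo sapiens) for antiproliferative activity, read by MTT assay, with a stated time of 24 h; on this read-out lower numbers stand for stronger inhibition and higher numbers for weaker inhibition:
- compound 1 `CCn1c(C(=O)N[C@@H](C)C(=O)OC)ccc1C(CC)(CC)c1ccc(OCS(=O)(=O)c2ccccc2)c(C)c1`: 17900 nM
- compound 2 `CCn1c(C(=O)NCCNC(=O)OC(C)(C)C)ccc1C(CC)(CC)c1ccc(OCS(=O)(=O)c2ccccc2)c(C)c1`: > 50000 nM (a limit)
- compound 3 `CCn1c(C(=O)N[C@H](CO)CCCO)ccc1C(CC)(CC)c1ccc(OCS(=O)(=O)c2ccccc2)c(C)c1`: > 50000 nM (a limit)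

Compound 3 has no exact number, only the limit > 50000 nM. This is the shared ceiling of the series, (the limit of > 50000 nM in this assay, at which 2 of the 3 values shown sit).

Compound 4 `CCn1c(C(=O)NCCC(=O)O)ccc1C(CC)(CC)c1ccc(OCS(=O)(=O)c2ccccc2)c(C)c1` keeps the shared core and alters only the amide side chain, with 2-carboxyethyl entering: a group of 5 heavy atoms (3 carbon, 2 oxygen; no ring) in place of a group of 7 heavy atoms (5 carbon, 2 oxygen; no ring), on an amide-type nitrogen.

Among the measured compounds shown here, two measured steps bear on this change: an at least 2.7-fold higher number from compound 1 to compound 2 (0.44 log units; beyond the scatter), and an at least 2.7-fold higher number from compound 1 to compound 3 (0.44 log units; beyond the scatter). Both swap the amide side chain of compound 1 and end at the limit. Neither introduces 2-carboxyethyl, so the guidance is indirect.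

Compound 4 is therefore expected to stay near the limit, with no firm direction: a number no higher from compound 3 to compound 4 (the limit leaves the size open). Compound 4 is estimated at 50000 nM, with an expected range of 20000 nM to 100000 nM.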

Compound 4, half-maximal inhibitory concentration: > 50000 nM
Compound 4: only a limit was reported; the forecaster's own chance of this, stated with the estimate: 60%; the middle value sits exactly at the limit.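

With 2-carboxyethyl on the amide-type nitrogen, compound 4 joins compound 2 and compound 3 at the shared ceiling: the limit of > 50000 nM in this assay, at which 3 of the 4 values shown sit.

Among the compounds shown here, measured against the only exact value, this side chain gives an at least 2.7-fold higher number from compound 1 to compound 4 (0.44 log units; beyond the scatter). The steps among the three limits cannot be read, so these side chains cannot be ranked against one another.

On these data alone, it remains open how an amine or a longer chain ending in a carboxylic acid would read on this nitrogen. The compounds shown also leave open whether any side chain can give a lower number than compound 1.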